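Methyl on the pyridin-4-yl of compound 3: efficacy outlook

The compounds below may be only part of what the source reports. "The series", "measured", "known", "first", "only" and "open" are said of these compounds alone.

Working notes on the maximal-response read-out. In an in vitro functional assay on HEK285-7 cells for antagonist activity at prostaglandin D2 receptor 2 (Homo sapiens), read by BRET and beta-arrestin recruitment (on this read-out higher numbers stand for larger maximal responses and lower numbers for smaller maximal responses), compound 1 `O=C(O)Cc1sc(C(c2ccccc2)c2ccccc2)nc1-c1ccccc1` gives 80%. Compound 2 `O=C(O)Cc1sc(C(c2ccc(F)cc2)c2ccc(F)cc2)nc1-c1ccnc(N2CCCC2)c1`, carrying two fluorophenyl groups and a pyrrolidin-1-yl-substituted ring, gives 80%, and compound 3 `O=C(O)Cc1sc(C(c2ccc(F)cc2)c2ccc(F)cc2)nc1-c1ccncc1` gives 80%. Among the compounds with values here, the only single-point step measured so far, no change at the digits printed from compound 2 to compound 3 (within the scatter), is hydrogen in place of pyrrolidin-1-yl on an aromatic carbon. Compound 3 therefore stands level with compound 1 and compound 2 at the digits shown; the three efficacies cannot be ordered.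

Compound 4 `Cc1cc(-c2nc(C(c3ccc(F)cc3)c3ccc(F)cc3)sc2CC(=O)O)ccn1` is the next step from compound 3: methyl in place of hydrogen on an aromatic carbon, which read one bond further out is pyridin-4-yl to 2-methylpyridin-4-yl. Within the data shown here, no measured step adds or removes a methyl. The one step on the same ring, no change at the digits printed from compound 2 to compound 3 (within the scatter), was flat within the scatter, and the series as a whole has shown no movement in this read-out. No step beyond the scatter is expected in this assay, so for compound 4 the expected value is 80%, with a range of 68% to 92%. The expected step of no change at the digits printed from compound 3 to compound 4 (within the scatter) is thus essentially nil.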

Compound 4, largest response reached (reported as efficacy), in percent of the reference or control that the assay uses: 80%
Compound 4: the middle estimate sits on the measured number at the digits printed; the range from low to high includes it.
By their numbers in this assay, from the lowest: compounds 1, 2, 3 and 4 (each within the scatter of the next).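

In this assay, within the data shown here, methyl in place of hydrogen next to the ring nitrogen gives no change at the digits printed from compound 3 to compound 4 (within the scatter) and is the first measured step to add a methyl, so the 2-methylpyridin-4-yl compound joins the flat set. Methyl in place of pyrrolidin-1-yl gives no change at the digits printed from compound 2 to compound 4 (within the scatter) at the same place, which leaves hydrogen, methyl and pyrrolidin-1-yl there with no order among compounds 2, 3 and 4. No supporting measurement is available to explain this flat behaviour at the position.

Going by these compounds, whether a primary amine, a carboxylic acid, a hydroxyl or a trifluoromethyl at this place would shift this assay remains open. Also open is whether a methyl elsewhere on the six-membered aromatic ring would read the same, since every step shown stays within the scatter.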